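A few compounds are considered here, and "the series" means these few. Any claim that something is new, unique, unknown or untested is made for them only; others in the source may bear on it.

Of the compounds shown here, three have been measured: compound 1 `Cc1c(OCCCCOc2ccccc2C(=O)O)ccc(C(=O)CC2CCCC2)c1C`, compound 2 `Cc1c(OCCCCOc2cccc(C(=O)O)c2)ccc(C(=O)CC2CCCC2)c1O` and compound 3 `Cc1c(OCCCCOc2cccc(C(=O)O)c2)ccc(C(=O)CC(C)C)c1O`. In an assay on HEK293 cells for positive allosteric modulation of metabotropic glutamate receptor 2 (Rattus norvegicus), read by thallium flux, with a stated time of 2.5 min (a lower number here means a smaller maximal response, a higher number a larger maximal response), compound 1 gives 67.1%, compound 2 gives 80.6% and compound 3 gives 84.5%. Compound 2 thus stands second highest of the three numbers; compound 3 lies close to it, within the usual scatter, while compound 1 lies lower, beyond the scatter. Compound 1 and compound 2 differ in more than one place, so their gap is not assigned to a single change. For the measured compounds named here, the only single-change step measured, a number 3.9 percentage points higher from compound 2 to compound 3 (within the scatter), concerns the group on the saturated chain carbon bound to the carbonyl carbon.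

Compound 4 `Cc1c(OCCCCOc2ccc(F)c(C(=O)O)c2)ccc(C(=O)CC2CCCC2)c1O` differs from compound 2 by fluoro in place of hydrogen on an aromatic carbon. Going by the values given here, no measured step touches this position, so nothing in the data bears directly on it; the one single-change step that exists stayed within the scatter. The step expected in this assay is a number 0.6 percentage points lower from compound 2 to compound 4 (within the scatter), which is no change beyond the scatter. Compound 4 is therefore estimated at 80%, with a range from 66% to 92%.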

Compound 4, largest response reached (reported as percent of maximum), in percent of the reference or control that the assay uses: 81%
Beside the measured number, compound 4's estimate is 1 percentage points below it; low and high end bracket the measured number.
By their numbers in this assay, from the lowest: compound 1; then compounds 2, 4 and 3 (each within the scatter of the next).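

Fluoro in place of hydrogen on this aromatic carbon, ortho to a carboxy group and para to a large group, gives a number 0.4 percentage points higher from compound 2 to compound 4 (within the scatter) in this assay. For the compounds shown here, this is the first measured evidence for this position: in the step from 3-carboxyphenyl to 3-carboxy-4-fluorophenyl, the maximal response shows no change beyond the scatter. No supporting measurement is available to explain this outcome.

The compounds shown leave open whether chloro, methoxy or an amine on the same aromatic carbon would also stay within the scatter, and whether fluoro would do so on the other carbons of this ring. They also do not show which of the differences between compound 1 and compound 2 accounts for the gap between their values.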